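The source may report more compounds than this note shows. Statements on the series, on what has been measured and on what is new or still open speak of the compounds shown alone.

Measured compounds:
Compound 1, `Cc1oc(=O)oc1COC(=O)c1cccc(NC(=O)[C@@H]2C[C@H](SC3=C(C(=O)O)N4C(=O)[C@H]([C@@H](C)O)[C@H]4[C@H]3C)CN2)c1`. In an ADME assay for metabolic stability, read by LC-MS, with a stated time of 3 h, at pH 6.5, tested at 50 uM (a higher number here means that more of the compound is left, a lower number that less of the compound is left), compound 1 gives > 95%, which is a limit of the assay and not a number.
Compound 2, `CCOC(=O)c1cccc(NC(=O)[C@@H]2C[C@H](SC3=C(C(=O)O)N4C(=O)[C@H]([C@@H](C)O)[C@H]4[C@H]3C)CN2)c1`. In this assay compound 2 gives > 95%, again a limit.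
Compound 3, `C[C@@H](O)[C@H]1C(=O)N2C(C(=O)O)=C(S[C@@H]3CN[C@H](C(=O)Nc4cccc(C(=O)OCC(F)(F)F)c4)C3)[C@H](C)[C@H]12`. In this assay compound 3 gives > 95%, also a limit.

Compound 3 therefore stands at the top of what the assay reports, together with the other two values: the limit of > 95% in this assay, at which 3 of the 3 values shown sit. None of the steps between the measured compounds can be sized: a step that the two limits leave unreadable from compound 1 to compound 2; a step that the two limits leave unreadable from compound 1 to compound 3; a step that the two limits leave unreadable from compound 2 to compound 3. All three alter the same place, the saturated chain carbon bound to an oxygen next to a carbonyl group, and all three leave every compound at the limit.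

Compound 4, `CC(C)C(=O)OCOC(=O)c1cccc(NC(=O)[C@@H]2C[C@H](SC3=C(C(=O)O)N4C(=O)[C@H]([C@@H](C)O)[C@H]4[C@H]3C)CN2)c1`, differs from compound 3 by (isopropylcarbonyl)oxy in place of trifluoromethyl on a saturated chain carbon bound to an oxygen next to a carbonyl group. The change sits at the same place as the three measured steps, none of which moved the read-out off the limit, and compound 1, which carries a larger group there, also gives a value at the limit. In this assay compound 4 is therefore expected near 94%, between 80% and 100%. The expected step of a number at least 1 percentage points lower from compound 3 to compound 4 (that floor lies within the scatter) is thus no movement beyond the scatter, with the reported value most likely again a limit.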

Compound 4, percent of the compound remaining: > 95%
Compound 4 ended at the assay's limit (the forecaster's own chance of this, stated with the estimate: 70%); at least 1 percentage points between middle value and limit.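

The steps from compound 1, compound 2 and compound 3 to compound 4 cannot be read, because all four compounds share one limit: the limit of > 95% in this assay, at which 4 of the 4 values shown sit.
On these data alone, whether any group on the saturated chain carbon bound to an oxygen next to a carbonyl group moves a compound off that limit in this assay stays open.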